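From cyclohexyl to 3-chlorophenyl on compound 1

A few compounds are considered here, and "the series" means these few. Any claim that something is new, unique, unknown or untested is made for them only; others in the source may bear on it.

Of the compounds shown here, three have been measured in a functional assay on KB 3-1 cells (Homo sapiens) for cytotoxicity, read by MTT assay, with a stated time of 72 h; a lower number here means a stronger inhibitor, a higher number a weaker inhibitor: compound 1 `O=C1Nc2ccccc2/C1=N/NC(=S)NC1CCCCC1` gives 9140 nM, compound 2 `COc1ccccc1NC(=S)N/N=C1\C(=O)Nc2ccccc21` gives 4960 nM and compound 3 `COc1cc(NC(=S)N/N=C2\C(=O)Nc3ccccc32)cc(OC)c1OC` gives 11100 nM. The number for compound 1 falls inside the span of the other two and lies within the scatter of each.

Compound 4 `O=C1Nc2ccccc2/C1=N/NC(=S)Nc1cccc(Cl)c1` has not been measured. It carries 3-chlorophenyl in place of cyclohexyl on an amide-type nitrogen. Going by the values given here, no measured step isolates this kind of change. Compound 2 at 4960 nM and compound 3 at 11100 nM both bear a substituted phenyl on that nitrogen, and their numbers lie on either side of compound 1 at 9140 nM. No clear direction is therefore expected, and no step beyond the scatter is expected in this assay. The expected step is a 1.5-fold lower number from compound 1 to compound 4 (0.18 log units; within the scatter). For compound 4 the estimated value is 6000 nM, with an expected range of 2200 nM to 14000 nM.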

Compound 4, half-maximal inhibitory concentration: 1870 nM
For compound 4 the middle estimate is 3.2-fold (0.51 log units) above the measured one; the whole stated range lies above it.
By their numbers in this assay, from the lowest: compound 4; then compounds 2, 1 and 3 (each within the scatter of the next, the first and the last beyond it).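

In this assay, going by these compounds alone, the exchange of cyclohexyl for 3-chlorophenyl on the amide-type nitrogen gives a 4.9-fold lower number from compound 1 to compound 4 (0.69 log units; beyond the scatter) as the first isolated step at this position. The earlier compounds shown here offered no such step, and this one shows that the group on this nitrogen, next to nothing else changed in the core of compound 1, can move the number beyond the scatter, here with an aromatic ring carrying chlorine entering for a non-aromatic ring of carbon only. Nothing available explains the step.

Within the data shown here, the single change carries both the aromatic ring and the chlorine, and their shares remain unseparated; an unsubstituted phenyl on this nitrogen would divide them. Also open, as far as these compounds go, is how a benzyl group or a bromine-bearing phenyl would read at this position.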